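Methyl for Chloro at the Weak End of the Series

The source may report more compounds than this note shows. Statements on the series, on what has been measured and on what is new or still open speak of the compounds shown alone.

Three close relatives of one shared core have been tested in an ADME assay on HUVEC cells (Homo sapiens) for antiproliferative activity, read by MTT assay, with a stated time of 48 h; on this read-out higher numbers stand for weaker inhibition and lower numbers for stronger inhibition. Compound 1 `N#CC1=C(N)Oc2c(N)cc3nc4ccccc4nc3c2C12C(=O)N(Cc1cnnn1-c1ccccc1Br)c1ccccc12` carries a 2-bromophenyl on an aromatic nitrogen, and in this assay compound 1 gives 34200 nM. Compound 2 `N#CC1=C(N)Oc2c(N)cc3nc4ccccc4nc3c2C12C(=O)N(Cc1cnnn1-c1ccc(Cl)cc1Cl)c1ccccc12` carries a 2,4-dichlorophenyl in that place. For compound 2 the result is only a limit of the assay, > 50000 nM. Compound 3 `N#CC1=C(N)Oc2c(N)cc3nc4ccccc4nc3c2C12C(=O)N(Cc1cnnn1-c1cc(Cl)ccc1Cl)c1ccccc12` carries a 2,5-dichlorophenyl there. For compound 3 too the result is a limit of the assay, > 50000 nM. Compound 3 thus stands at the weak end of what the assay can read, with no exact number. The measured steps are small: an at least 1.4-fold higher number from compound 1 to compound 2 (0.16 log units; that floor lies within the scatter) and an at least 1.4-fold higher number from compound 1 to compound 3 (0.16 log units; that floor lies within the scatter), while a step that the two limits leave unreadable from compound 2 to compound 3. The picture is set by the limit of > 50000 nM in this assay, at which 2 of the 3 values shown sit.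

Compound 4 `Cc1ccc(Cl)cc1-n1nncc1CN1C(=O)C2(C(C#N)=C(N)Oc3c(N)cc4nc5ccccc5nc4c32)c2ccccc21` differs from compound 3 by methyl in place of chloro on an aromatic carbon, so that 2,5-dichlorophenyl becomes 5-chloro-2-methylphenyl on that aromatic nitrogen. Among the compounds with values here, none of the measured steps involves a methyl, and the steps that do alter this ring stay within the scatter or cannot be read. No movement beyond the scatter is expected for compound 4, an estimated step that the limit leaves unreadable from compound 3 to compound 4. In this assay compound 4 is therefore expected to give about 60000 nM, within 30000 nM to 150000 nM, most likely reported again only as a limit.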

Compound 4, half-maximal inhibitory concentration: > 50000 nM
Compound 4 was reported as a limit (the forecaster's own chance of this, stated with the estimate: 70%); the middle value is on the limit's open side.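

Within the data shown here, a methyl on this aromatic carbon, ortho to a large group, is a new kind of substituent here, since the earlier compounds showed only halogens on the ring at that place. In this assay compound 4 also ends as a limit of the assay, > 50000 nM, so the swap of chloro for methyl brings no exact number. The one readable step is an at least 1.4-fold higher number from compound 1 to compound 4 (0.16 log units; that floor lies within the scatter), while the steps reaching compound 4 from compound 2 and compound 3 cannot be read, which leaves the series pressed against a single boundary: the limit of > 50000 nM in this assay, at which 3 of the 4 values shown sit.

As far as these compounds go, whether chloro and methyl truly differ at this place stays open, as does the question of how far past the limit of the assay either of them lies. From the compounds shown here alone, it is also open whether a plain hydrogen, an amine or a carboxylic acid on the same aromatic carbon would give an exact number in this assay, one that could then be set against the exact value of compound 1, 34200 nM.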